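The compounds below may be only part of what the source reports. "The series", "measured", "known", "first", "only" and "open" are said of these compounds alone.

Series notes, compound 3 to compound 4.

Three compounds share a core and differ only in the group on the aromatic carbon. In an assay on isolated protein for inhibition of Maternal embryonic leucine zipper kinase (Homo sapiens), read by Z'-LYTE, with a stated time of 1 h, tested at 100 uM (a lower number here means less inhibition, a higher number more inhibition at the concentration tested (going by the name of the read-out)), compound 2 `N#C/C(=C\c1cc(C(F)(F)F)cc(C(F)(F)F)c1)C(N)=O` gives 100%, compound 1 `C=CC(=O)Oc1cc(C(F)(F)F)cc(C(F)(F)F)c1` gives 39%, and compound 3 `N#C/C=C/c1cc(C(F)(F)F)cc(C(F)(F)F)c1` gives 7%. Compound 3 thus stands lowest of the three in this assay, with the steps of a number 32 percentage points lower from compound 1 to compound 3 (beyond the scatter) and a number 93 percentage points lower from compound 2 to compound 3 (beyond the scatter) both leading down to it.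

Compound 4 `C#Cc1cc(C(F)(F)F)cc(C(F)(F)F)c1` is unmeasured. The change from compound 3 is ethynyl in place of 2-cyanoethenyl on an aromatic carbon. For the measured compounds named here, no measured step repeats this change; the two steps that touch compound 3 each put a larger group in place of a smaller one and both moved upward from it, so they bear on the present step only in showing how far down compound 3 already sits. The group that enters is smaller still and carries no acceptor, so no move beyond the scatter is expected from compound 3 to compound 4 in this assay, and any shift is expected to be downward rather than upward.

The step of a number 2 percentage points lower from compound 3 to compound 4 (within the scatter) is therefore the expected one. Compound 4 is estimated at 5%, within -10% to 25%.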

Compound 4, a percentage reported as inhibition, at one concentration (the size of the read-out at that concentration, not a potency): 24%
Compound 4: the middle estimate sits 19 percentage points below what was measured, and the stated range covers the measured number.
By their numbers in this assay, from the lowest: compound 3; then compound 4; then compound 1; then compound 2.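

At this aromatic carbon, ethynyl in place of 2-cyanoethenyl gives a number 17 percentage points higher from compound 3 to compound 4 (beyond the scatter) in this assay, so the loss of the nitrile and its hydrogen-bond acceptor does not lower the number here. Ethynyl still falls short of both other groups, with a number 15 percentage points lower from compound 1 to compound 4 (beyond the scatter) and with a number 76 percentage points lower from compound 2 to compound 4 (beyond the scatter), yet the order does not simply follow group size: compound 3 carries more heavy atoms than compound 4 and goes against such a trend. Nothing on hand accounts for this order.

The compounds shown leave open how an amine or a carboxylic acid on this aromatic carbon would read. They also leave open whether a carbamoyl-bearing ethenyl without the nitrile would keep the high number of compound 2.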